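A nitro added to a sulfonamide that showed no inhibition

This account rests on a few compounds, and the source may have more. Where it says the series, first, only, none or still open, it means among the compounds named here.

Measured so far:
Compound 1, `O=S(=O)(Nc1ccc2oc(-c3ccccc3)nc2c1)c1ccc(Cl)cc1`, in an assay on cells for inhibition of HSP60/HSP10 (Homo sapiens), with a stated time of 60 min (a lower number here means a stronger inhibitor, a higher number a weaker inhibitor), gives > 100000 nM, which is a limit of the assay and not a number.
Compound 2, `COc1ccccc1S(=O)(=O)Nc1ccc2oc(-c3ccccc3)nc2c1`, gives > 100000 nM, again a limit rather than a number.

Compound 1 therefore stands only at a limit in this assay; it showed no measurable inhibition. For the measured compounds named here, the one measured step, a step that the two limits leave unreadable from compound 1 to compound 2, is unreadable because both ends sit at the limit of > 100000 nM in this assay, at which 2 of the 2 values shown sit.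

Compound 3, `O=[N+]([O-])c1cc(S(=O)(=O)Nc2ccc3oc(-c4ccccc4)nc3c2)ccc1Cl`, differs from compound 1 by nitro in place of hydrogen on an aromatic carbon. Going by the values given here, no measured step involves a nitro group, and the single step on record gives no readable size. The expectation for compound 3 is thus anchored only in the limit of compound 1, so the step of a number no higher from compound 1 to compound 3 (the limit leaves the size open) is expected to be none beyond the scatter. Compound 3 is estimated at 100000 nM, with a range from 30000 nM to 300000 nM, most likely reported again as a limit.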

Compound 3, half-maximal inhibitory concentration: 17000 nM
Estimate against measurement, compound 3: 5.9-fold (0.77 log units) above; measured number outside the range, below it.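

Nitro in place of hydrogen on this aromatic carbon, ortho to a chloro group and meta to a large group, gives an at least 5.8-fold lower number from compound 1 to compound 3 (0.76 log units; beyond the scatter) in this assay. This is the first readable signal among these compounds: a change on this ring can bring the number down from the limit, which the swap of 4-chlorophenyl for 2-methoxyphenyl could not show. Compound 1 gives > 100000 nM, a limit and not a number, and the true size of the step stays unknown because it starts from that limit: the limit of > 100000 nM in this assay, at which 2 of the 3 values shown sit.

The compounds shown leave open whether an amine or a nitrile on the same carbon would lower the number as well, and whether nitro depends on the chloro group. Going by these compounds, whether nitro would have any such effect on the 2-methoxyphenyl ring of compound 2 also stays open.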